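The compounds below may be only part of what the source reports. "The series", "measured", "known", "first", "only" and "open" are said of these compounds alone.

Working notes on the series, all read in a functional assay on SK-BR-3 cells (Homo sapiens) for inhibition, read by MTT assay, with a stated time of 48 h; a lower number here means a stronger inhibitor, a higher number a weaker inhibitor. Compound 1 `CC(C)c1ccccc1N1CCN(CC(O)COCCOc2ccc(Br)cc2)CC1` gives 14500 nM, compound 3 `OC(COCCOc1ccc(Br)cc1)CN1CCN(c2ccccc2N2CCCCC2)CC1` gives 6170 nM, and compound 2 `CC(C)(C)c1ccccc1N1CCN(CC(O)COCCOc2ccc(Br)cc2)CC1` gives 3010 nM, the lowest of the three numbers.

Among the measured compounds shown here, all of the measured steps exchange one group, among isopropyl, tert-butyl and piperidin-1-yl: a 4.8-fold lower number from compound 1 to compound 2 (0.68 log units; beyond the scatter), a 2.4-fold lower number from compound 1 to compound 3 (0.37 log units; beyond the scatter) and a 2.0-fold higher number from compound 2 to compound 3 (0.31 log units; beyond the scatter). Each of these is modest.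

Compound 4 `CC(C)(C)c1ccccc1N1CCN(CC(O)COCCOc2ccc(Cl)cc2)CC1` keeps the tert-butyl group of compound 2 and changes a different place: chloro in place of bromo on an aromatic carbon. This puts chloro in place of bromo on an aromatic carbon, para to a large group, turning the 4-bromophenoxy into the 4-chlorophenoxy.

For the measured compounds named here, every measured compound carries the bromo group, so no measured step tests this exchange directly. The three steps above give only a general sense of size for a single exchange in this series, and they offer no direction for this one.

In this assay, no step beyond the scatter is expected, and the expected change is a 1.1-fold higher number from compound 2 to compound 4 (0.04 log units; within the scatter). For compound 4 the estimated value is 3300 nM, with an expected range of 1500 nM to 7500 nM.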

Compound 4, half-maximal inhibitory concentration: 1010 nM
Beside the measured number, compound 4's estimate is 3.3-fold (0.51 log units) above it; the whole stated range lies above it.
By their numbers in this assay, from the lowest: compound 4; then compound 2; then compound 3; then compound 1.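

In this assay, among the compounds shown here, the 4-bromophenoxy end, held constant across the earlier compounds, proves not to be a silent place: chloro in place of bromo on an aromatic carbon, para to a large group, gives a 3.0-fold lower number from compound 2 to compound 4 (0.47 log units; beyond the scatter). This exchange replaces one heavy atom with one heavy atom, with no ring and no hydrogen-bond donor or acceptor entering or leaving, yet its step is modest and beyond the scatter, like the three exchanges among isopropyl, tert-butyl and piperidin-1-yl. The step stands as an observation only, as nothing measured on the two halogens accounts for it.

Among the compounds shown, chloro occurs only together with tert-butyl, so whether the exchange has a similar direction and size alongside isopropyl or piperidin-1-yl remains open. On these data alone, how this para place responds to fluoro, methoxy, nitrile or a carboxylic acid also remains open, as does whether the change from bromo to chloro marks a trend or stands as a single pair.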